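Changing the amide aryl group of compound 3

The source may report more compounds than this note shows. Statements on the series, on what has been measured and on what is new or still open speak of the compounds shown alone.

In a functional assay on A549 cells (Homo sapiens) for cytotoxicity, read by MTT assay, with a stated time of 72 h (a lower number here means a stronger inhibitor, a higher number a weaker inhibitor), three amides built on a shared core have been measured. Compound 1 `O=C(CN1CCN(c2nnc(Cc3ccccc3)c3ccccc23)CC1)Nc1c(F)cccc1F` gives 84500 nM, compound 2 `Cc1cccc(Cl)c1NC(=O)CN1CCN(c2nnc(Cc3ccccc3)c3ccccc23)CC1` gives 7420 nM, and compound 3 `O=C(CN1CCN(c2nnc(Cc3ccccc3)c3ccccc23)CC1)Nc1cc(C(F)(F)F)ccc1Cl` gives 89000 nM. Compound 3 therefore stands at the high end of these numbers, level with its nearest neighbour: a 1.1-fold higher number from compound 1 to compound 3 (0.02 log units; within the scatter). The next compound, compound 4 `Cc1ccc(NC(=O)CN2CCN(c3nnc(Cc4ccccc4)c4ccccc34)CC2)c(C)c1`, keeps the shared core and has 2,4-dimethylphenyl in place of 2-chloro-5-(trifluoromethyl)phenyl on an amide-type nitrogen.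

All three measured steps bear on this change, since each falls at that same place. Two of them are large: an 11-fold lower number from compound 1 to compound 2 (1.06 log units; beyond the scatter), and a 12-fold higher number from compound 2 to compound 3 (1.08 log units; beyond the scatter). This place can therefore move the number a long way, or hardly at all. Going by the values given here, no measured compound carries the 2,4-dimethylphenyl group. Only compound 2, at 7420 nM, has a methyl group on this ring, so it offers a partial guide towards a lower number. With so few compounds, a step smaller than the large ones is expected, and the expected step is a 3.2-fold lower number from compound 3 to compound 4 (0.50 log units; beyond the scatter). For compound 4 the estimated value in this assay is 28000 nM, with an expected range of 7000 nM to 100000 nM.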

Compound 4, half-maximal inhibitory concentration: "not active" (no number reported)
Nothing numeric was reported for compound 4, and the estimate cannot be compared.
By their numbers in this assay, from the lowest: compound 2; then compounds 1 and 3 (each within the scatter of the next).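

In this assay, going by these compounds alone, compound 4 is reported as "not active" with no number, so no step between compound 3 and compound 4 can be read. As far as these compounds go, whether the number for the 2,4-dimethylphenyl amide would lie beyond that of compound 3 remains open. No measurement given here offers an explanation for this result.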